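Propanoyl on the sulfonamide nitrogen of compound 2

This account rests on a few compounds, and the source may have more. Where it says the series, first, only, none or still open, it means among the compounds named here.

In a functional assay on the whole organism (strain Wistar) with Rattus norvegicus as the target, read by paw edema (on this read-out higher numbers stand for an effect only at larger amounts of compound and lower numbers for an effect already at smaller amounts), compound 2 `NS(=O)(=O)c1ccc(-n2nc(C(F)(F)F)cc2-c2ccc3c(c2)CCO3)cc1CO` gives 22.3 mg/kg. Compound 1 `CCC(=O)NS(=O)(=O)c1ccc(-n2nc(C(F)(F)F)cc2-c2ccc(OC)c(C)c2)cc1CO` gives 6.2 mg/kg in the same test. Compound 2 thus holds the higher of the two numbers, and the gap between them lies beyond the scatter. Compound 3 `CCC(=O)NS(=O)(=O)c1ccc(-n2nc(C(F)(F)F)cc2-c2ccc3c(c2)CCO3)cc1CO` has propanoyl in place of hydrogen on a sulfonamide nitrogen of compound 2. Among the compounds with values here, no measured pair shows this change alone. Within the data shown here, compound 1 also bears propanoyl there, differs elsewhere, and gives 6.2 mg/kg as the only guide. In this assay the estimated step of a 2.8-fold lower number from compound 2 to compound 3 (0.45 log units; beyond the scatter) is expected toward a lower number, beyond the scatter. Compound 3 is expected at 8 mg/kg in a range from 3.5 mg/kg to 18 mg/kg on this estimate.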

Compound 3, dose for half-maximal effect: 7.5 mg/kg
For compound 3 the middle estimate is 1.1-fold (0.03 log units) above the measured one, and the stated range covers the measured number.
By their numbers in this assay, from the lowest: compounds 1 and 3 (each within the scatter of the next); then compound 2.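

In this assay, within the data shown here, propanoyl in place of hydrogen on a sulfonamide nitrogen now stands as the only change in a measured pair, giving a 3.0-fold lower number from compound 2 to compound 3 (0.47 log units; beyond the scatter). With propanoyl on that nitrogen, exchanging the two groups on an aromatic carbon gives a 1.2-fold higher number from compound 1 to compound 3 (0.08 log units; within the scatter), so compound 1 and compound 3 cannot be told apart here. Nothing measured here accounts for the step on the sulfonamide nitrogen.

On these data alone, whether acetyl, butanoyl or benzoyl on that nitrogen would give a different number remains open. So does the size of the propanoyl step on the core of compound 1, whose unsubstituted sulfonamide is not among the compounds shown.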